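The source may hold more compounds than are shown below. What is called first, only, known or untested is meant among the compounds shown, and "the series" means these compounds.

Compound 3 `CC1(C)Cc2c(sc(NC(=O)C(C)(C)O)c2C(N)=O)C(C)(C)O1` holds the lowest number of the three measured compounds in an assay on cells for positive allosteric modulation of Cystic fibrosis transmembrane conductance regulator variant F508del (Homo sapiens), with stated times of 10 min and 7 s, in the presence of a further agent that is not named here (a higher number here means that more compound is needed for the effect, a lower number that less compound is needed), where compound 3 gives 16 nM. Compound 2 `CC1(C)Cc2c(sc(NC(=O)C3CCNC3=O)c2C(N)=O)C(C)(C)O1` gives 101 nM in this assay, and compound 1 `CC1(C)Cc2c(sc(NC(=O)c3nnc[nH]3)c2C(N)=O)C(C)(C)O1` gives 467 nM; the steps were a 6.3-fold lower number from compound 2 to compound 3 (0.80 log units; beyond the scatter) and a 29-fold lower number from compound 1 to compound 3 (1.47 log units; beyond the scatter). Compound 4 `Cc1cn[nH]c1C(=O)Nc1sc2c(c1C(N)=O)CC(C)(C)OC2(C)C` differs from compound 3 in one place: 4-methyl-1H-pyrazol-5-yl in place of 1-hydroxy-1-methylethyl on a carbonyl carbon. For the measured compounds named here, the step that bears most directly on this change is the one from compound 1, which carries another five-membered aromatic ring with nitrogen atoms on the same carbonyl carbon: a 29-fold lower number from compound 1 to compound 3 (1.47 log units; beyond the scatter). Compound 4 reverses that direction, exchanging the 1-hydroxy-1-methylethyl group for a ring of that kind, so a modest to large rise in the number is expected, though the 4-methyl-1H-pyrazol-5-yl ring is not the ring of compound 1 and may not reach its number. For compound 4 the expected step is therefore an 8.1-fold higher number from compound 3 to compound 4 (0.91 log units; beyond the scatter), and the estimate in this assay is 130 nM, with a range from 35 nM to 500 nM.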

Compound 4, half-maximal effective concentration: 2 nM
The estimate for compound 4 lay 65-fold (1.81 log units) above the measured number; measured number below the stated range.
By their numbers in this assay, from the lowest: compound 4; then compound 3; then compound 2; then compound 1.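

In this assay, putting a five-membered aromatic ring with nitrogen atoms on this carbonyl carbon does not by itself raise the number, as an 8.0-fold lower number from compound 3 to compound 4 (0.90 log units; beyond the scatter) runs opposite to the direction that compound 1 had suggested. The identity of the ring matters greatly at this position, with a 230-fold lower number from compound 1 to compound 4 (2.37 log units; beyond the scatter) between two such rings, and the open 1-hydroxy-1-methylethyl group and the 2-oxopyrrolidin-3-yl ring are also surpassed, the latter in a 51-fold lower number from compound 2 to compound 4 (1.70 log units; beyond the scatter). Nothing available here accounts for these differences.

The compounds shown leave open how much of the gain belongs to the ring and how much to its methyl group, which a plain 1H-pyrazol-5-yl group would help separate. They also leave open whether an ethyl group or a chlorine atom in place of that methyl would hold the number.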